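A halogen swap on the pendant phenyl ring

The compounds below may be only part of what the source reports. "The series", "measured", "known", "first", "only" and "open" are said of these compounds alone.

Among the compounds with values here, compound 3 `O=Cc1c(-c2ccc(F)cc2)nc2sc(Cc3ccc(Cl)cc3)nn12` gives 17000 nM in an ADME assay on CCRF-CEM cells (Homo sapiens) for cytotoxicity, with a stated time of 72 h (a higher number here means a weaker inhibitor, a lower number a stronger inhibitor), and that is the only actual number among the three values shown. For compound 1 `Fc1ccc(-c2cn3nc(Cc4ccc(Cl)cc4)sc3n2)cc1` this assay reports only a limit, > 250000 nM. For compound 2 `Clc1ccc(Cc2nn3c(Br)c(-c4ccc(Cl)cc4)nc3s2)cc1` this assay likewise reports only a limit, > 250000 nM. Within the data shown here, the one measured step, an at least 14-fold lower number from compound 1 to compound 3 (1.16 log units; beyond the scatter), sets compound 3 apart from the two limit compounds, and that step rests on (the limit of > 250000 nM in this assay, at which 2 of the 3 values shown sit). Compound 4 `O=Cc1c(-c2ccc(Cl)cc2)nc2sc(Cc3ccc(Cl)cc3)nn12` differs from compound 3 by chloro in place of fluoro on an aromatic carbon. Among the measured compounds shown here, no measured step concerns a halogen on that ring; the only measured step concerns formyl in place of hydrogen, and compound 4 keeps the formyl group of compound 3. For the measured compounds named here, there is thus no measured precedent for this change, and the expected step in this assay from compound 3 to compound 4 is none beyond the scatter. Compound 4 is therefore estimated at 17000 nM, between 6000 nM and 50000 nM. The step this estimate means, no change at the digits printed from compound 3 to compound 4 (within the scatter), is expected to stay within the scatter.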

Compound 4, half-maximal inhibitory concentration: 5800 nM
Beside the measured number, compound 4's estimate is 2.9-fold (0.47 log units) above it; measured number below the stated range.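

With the formyl group held in place, the 4-fluorophenyl to 4-chlorophenyl change gives, in this assay, a 2.9-fold lower number from compound 3 to compound 4 (0.47 log units; beyond the scatter), so the halogen at this position moves the number, modestly but beyond the scatter, which no earlier step had shown. Formyl in place of bromo on an aromatic carbon gives an at least 43-fold lower number from compound 2 to compound 4 (1.63 log units; beyond the scatter), a second large step tied to the formyl group, this time on the 4-chlorophenyl compounds. This step starts from a limit: the limit of > 250000 nM in this assay, at which 2 of the 4 values shown sit.

The compounds shown leave open whether the number would keep moving with a bromo, a methoxy group or a nitrile in place of the halogen on that ring. They also leave open how a carboxylic acid, an amine or a hydroxymethyl group would read in place of the formyl group.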